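Swapping Chloro for Trifluoromethyl in Compound 2

A few compounds are considered here, and "the series" means these few. Any claim that something is new, unique, unknown or untested is made for them only; others in the source may bear on it.

Compound 1 `Nc1sc2c(c1-c1nc3cc(Cl)ccc3s1)CCCC2` gives 43.5 ug/mL
Compound 2 `Clc1ccc(/C=N/c2sc3c(c2-c2nc4ccccc4s2)CCCC3)cc1` gives 367 ug/mL

Going by the values given here, both values come from an ADME assay on cells (Rhabdomyosarcoma cell, Homo sapiens) for cytotoxicity, read by MTT assay, with a stated time of 72 h (on this read-out higher numbers stand for lower toxicity in this test and lower numbers for higher toxicity in this test), and they are the only two numbers available. Compound 2 holds the higher number, and compound 1 lies below it by a gap beyond the scatter. The two compounds differ in more than one place, so that gap says nothing about any single change.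

The next compound to be tested is compound 3 `FC(F)(F)c1ccc(/C=N/c2sc3c(c2-c2nc4ccccc4s2)CCCC3)cc1` which differs from compound 2 in one place. The change is trifluoromethyl in place of chloro on an aromatic carbon and in words it is trifluoromethyl in place of chloro on an aromatic carbon. Among the compounds with values here, no measured pair shows what a change of this kind does, so the expectation rests on compound 2 alone, with its 367 ug/mL as the anchor. The expected step of a 1.1-fold lower number from compound 2 to compound 3 (0.05 log units; within the scatter) in this assay stays within the scatter, with neither direction favoured. The data cannot exclude a larger move, so the range is kept wide. In this assay the estimated value for compound 3 is 330 ug/mL with an expected range of 130 ug/mL to 800 ug/mL for this measurement.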

Compound 3, half-maximal cytotoxic concentration: 250 ug/mL
Compound 3: the middle estimate sits 1.3-fold (0.12 log units) above what was measured; the range from low to high includes it.
By their numbers in this assay, from the lowest: compound 1; then compounds 3 and 2 (each within the scatter of the next).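

In this assay, trifluoromethyl in place of chloro on an aromatic carbon gives a 1.5-fold lower number from compound 2 to compound 3 (0.17 log units; within the scatter), and this is the only single-place step among the compounds shown. It shows that, at this position on the six-membered aromatic ring of carbon only, para to a large group, going from 4-chlorophenyl to 4-(trifluoromethyl)phenyl replaces one heavy atom with four without moving the read-out beyond the scatter, although this rests on a single pair in a single assay. Nothing available explains this result, and no measurement bears on why the read-out stays within the scatter.

Going by these compounds, whether an amine, a carboxylic acid or a longer chain on the same aromatic carbon would also stay within the scatter remains open, since both groups seen at this position carry no hydrogen-bond donors or acceptors and no net charge. Also open is which part of the structure accounts for the gap between compound 1 and compound 2, as those two compounds differ in more than one place and no single-place step connects them.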